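From oxan-4-yl to (oxetan-3-yl)methyl at the limit

The compounds below may be only part of what the source reports. "The series", "measured", "known", "first", "only" and "open" are said of these compounds alone.

In a toxicity assay on HT-29 cells (Homo sapiens) for cytotoxicity (on this read-out higher numbers stand for lower toxicity in this test and lower numbers for higher toxicity in this test), compound 1 (`CN1C(=S)[C@@H](NC(=O)c2nc(Cc3ccccc3)n(C3COC3)n2)COc2ccccc21`) gives > 100000 nM, which is a limit of the assay. Compound 2 (`CN1C(=S)[C@@H](NC(=O)c2nc(Cc3ccccc3)n(C3CCOCC3)n2)COc2ccccc21`) gives > 100000 nM, also a limit. Going by the values given here, the only measured step is a step that the two limits leave unreadable from compound 1 to compound 2, and the series so far rests on (the limit of > 100000 nM in this assay, at which 2 of the 2 values shown sit). Compound 3 (`CN1C(=S)[C@@H](NC(=O)c2nc(Cc3ccccc3)n(CC3COC3)n2)COc2ccccc21`) carries (oxetan-3-yl)methyl in place of oxan-4-yl on an aromatic nitrogen. With no readable size in a step that the two limits leave unreadable from compound 1 to compound 2, nothing beyond the scatter is expected in this assay. The expected step is a number no higher from compound 2 to compound 3 (the limit leaves the size open). Compound 3 is estimated at 100000 nM, with an expected range of 40000 nM to 200000 nM.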

Compound 3, half-maximal cytotoxic concentration: > 100000 nM
Compound 3 gave a limit, no number; the forecaster's own chance of this, stated with the estimate: 85%; the middle value sits exactly at the limit.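

Going by these compounds alone, no step among compound 1, compound 2 and compound 3 can be read, since all three sit at a limit: the limit of > 100000 nM in this assay, at which 3 of the 3 values shown sit. Left open is how the three compare in this assay once a number replaces each limit.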